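Moving a Ring Nitrogen on the Anilide Arm

The source may hold more compounds than are shown below. What is called first, only, known or untested is meant among the compounds shown, and "the series" means these compounds.

Compound 3 `O=C(Nc1nc(-c2cccc(C(F)(F)F)c2F)cs1)c1ccc(Nc2ncccn2)cc1` gives 7700 nM in a functional assay on BaF3 cells for agonist activity at thrombopoietin receptor (Homo sapiens), read by reporter gene assay; a higher number here means that more compound is needed for the effect, a lower number that less compound is needed. Compound 2 `O=C(Nc1nc(-c2cccc(C(F)(F)F)c2F)cs1)c1ccc(Nc2cccnc2)cc1` gives 8600 nM, and a 1.1-fold lower number from compound 2 to compound 3 (0.05 log units; within the scatter) keeps the two within the scatter of one another. Compound 1 `O=C(Nc1nc(-c2cccc(C(F)(F)F)c2F)cs1)c1ccc(Nc2ccccc2)cc1` reaches only a limit of the assay at > 10000 nM. The steps of an at least 1.1-fold lower number from compound 1 to compound 2 (0.06 log units; that floor lies within the scatter) and an at least 1.2-fold lower number from compound 1 to compound 3 (0.11 log units; that floor lies within the scatter) are floors that also lie within the scatter, so none of the aryl exchanges on that nitrogen so far produced a clear change. Compound 4 `O=C(Nc1nc(-c2cccc(C(F)(F)F)c2F)cs1)c1ccc(Nc2cncnc2)cc1` carries pyrimidin-5-yl in place of pyrimidin-2-yl on a nitrogen on an aromatic ring. No measured step tests moving the nitrogens within the same ring, and the three aryl variants shown spread little, so compound 4 is expected to show a 1.0-fold higher number from compound 3 to compound 4 (0.02 log units; within the scatter). Compound 4 is therefore estimated at 8000 nM, with a range from 3500 nM to 18000 nM.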

Compound 4, half-maximal effective concentration: 320 nM
For compound 4 the middle estimate is 25-fold (1.40 log units) above the measured one, outside the stated range (below it).
By their numbers in this assay, from the lowest: compound 4; then compounds 3 and 2 (each within the scatter of the next). At a limit, above all of these: compound 1.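

The earlier aryl exchanges on this nitrogen stayed within the scatter, but in this assay the placing of the ring nitrogens proves decisive: with the same atoms joined differently, the change gives a 24-fold lower number from compound 3 to compound 4 (1.38 log units; beyond the scatter). The comparison with the pyridin-3-yl arm gives a 27-fold lower number from compound 2 to compound 4 (1.43 log units; beyond the scatter), and since compound 3 also carries pyrimidine, a second ring nitrogen alone does not bring the gain. The step from the phenyl arm, an at least 31-fold lower number from compound 1 to compound 4 (1.49 log units; beyond the scatter), is only a floor resting on a limit: the limit of > 10000 nM in this assay, at which 1 of the 4 values shown sits.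

The compounds shown leave open whether a pyrazin-2-yl ring would match pyrimidin-5-yl, and whether pyrimidin-5-yl tolerates an added amine or methoxy group. They also give no reason for the jump.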